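The source may report more compounds than this note shows. Statements on the series, on what has been measured and on what is new or still open speak of the compounds shown alone.

Measured so far, in a functional assay on T47D cells (Homo sapiens) for cytotoxicity, read by sulforhodamine B assay, with a stated time of 48 h; a higher number here means a weaker inhibitor of growth, a lower number a stronger inhibitor of growth:

Compound 1, `ClCc1ccccc1Cn1cnc2c(Cl)nc(Cl)nc21`, gives 5490 nM.
Compound 2, `ClCc1cccc(Cn2cnc3c(Cl)nc(Cl)nc32)c1`, gives 4460 nM.
Compound 3, `Nc1nc(Cl)c2ncn(Cc3ccccc3CCl)c2n1`, gives 83200 nM.

Compound 1 and compound 2 are built from the same atoms joined differently; the difference between the two cores is not broken down here. Their two values lie within the usual scatter of each other, so nothing can be said about which of the two is the stronger inhibitor of growth.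

Compound 3 is made from compound 1 by a single change, (amino in place of chloro on an aromatic carbon). That change produced a 15-fold higher number from compound 1 to compound 3 (1.18 log units; beyond the scatter), a large step toward weaker growth inhibition.

The compound not yet measured is compound 4, `Nc1nc(Cl)c2ncn(Cc3cccc(CCl)c3)c2n1`. It is made from compound 2 by amino in place of chloro on an aromatic carbon. Among the compounds with values here, this is the same change as the one from compound 1 to compound 3: the group that leaves, the group that enters and the place where it sits are described in the same words.

Since compound 2 sits within the scatter of compound 1, a step of similar size is expected here, because the same change gave a 15-fold higher number from compound 1 to compound 3 (1.18 log units; beyond the scatter). The step expected from compound 2 to compound 4 in this assay is estimated as a 15-fold higher number from compound 2 to compound 4 (1.18 log units; beyond the scatter). Compound 4 is therefore estimated at 67000 nM, expected to fall between 25000 nM and 180000 nM.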

Compound 4, concentration for total growth inhibition: 37200 nM
The estimate for compound 4 lay 1.8-fold (0.26 log units) above the measured number, within the range that was stated.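

In this assay, amino in place of chloro on an aromatic carbon gave an 8.3-fold higher number from compound 2 to compound 4 (0.92 log units; beyond the scatter), so the weakening of growth inhibition seen with the core of compound 1 appears again with the core of compound 2. Set side by side, the two steps cannot be told apart, and the change carries over from one core to the other with much the same size: the same change on two cores in this assay, a 15-fold higher number (1.18 log units; beyond the scatter) from compound 1 to compound 3 and an 8.3-fold higher number (0.92 log units; beyond the scatter) from compound 2 to compound 4, 1.8-fold (0.26 log units) apart, within the scatter of two such steps. Within the data shown here, this agreement rests on only two matched pairs in a single cell assay, whose cores are built from the same atoms joined differently, so it does not show that the step would keep its size on any other core, and it gives no reason why the change weakens growth inhibition.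

The compounds shown leave open whether another group in the same place, such as a methylamine, a hydroxyl or a methoxy group, would give a similar step or a different one. They also leave open whether the step of about this size would hold in other cell lines, since every number here comes from the same cells and the same read-out.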